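The source may report more compounds than this note shows. Statements on the series, on what has been measured and on what is new or still open speak of the compounds shown alone.

In an assay on HL-60 cells for agonist activity at vitamin D3 receptor (Homo sapiens), read by microscopy, with a stated time of 96 h (a lower number here means that less compound is needed, a higher number that more compound is needed for the effect), compound 1 `CCn1c(C(=O)NCCN(C)C)ccc1C(CC)(CC)c1ccc(OCC(O)C(C)(C)C)c(C)c1` gives 14 nM, while compound 2 `C#CCNC(=O)c1ccc(C(CC)(CC)c2ccc(OCC(O)C(C)(C)C)c(C)c2)n1CC` gives 240 nM. Among the measured compounds shown here, the only measured step, a 17-fold higher number from compound 1 to compound 2 (1.23 log units; beyond the scatter), puts compound 2 at the highest of the two numbers, with compound 1 its nearest neighbour. Compound 3 `CCn1c(C(=O)NCC(OC)OC)ccc1C(CC)(CC)c1ccc(OCC(O)C(C)(C)C)c(C)c1` differs from compound 2 by dimethoxymethyl in place of ethynyl on a saturated chain carbon bound to an amide-type nitrogen. That step brings back a larger group carrying acceptors at the same place where compound 1 lost its (dimethylamino)methyl, so an expected drop of a 4.0-fold lower number from compound 2 to compound 3 (0.60 log units; beyond the scatter) in this assay seems reasonable, though smaller than the measured step. Compound 3 is therefore estimated at 60 nM, within 15 nM to 240 nM.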

Compound 3, half-maximal effective concentration: 150 nM
Compound 3: middle estimate off by 2.5-fold (0.40 log units), on the low side; low and high end bracket the measured number.
By their numbers in this assay, from the lowest: compound 1; then compounds 3 and 2 (each within the scatter of the next).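

At the saturated chain carbon bound to an amide-type nitrogen, dimethoxymethyl in place of ethynyl gives a 1.6-fold lower number from compound 2 to compound 3 (0.20 log units; within the scatter), so this assay does not separate these two groups. Dimethoxymethyl in place of (dimethylamino)methyl gives an 11-fold higher number from compound 1 to compound 3 (1.03 log units; beyond the scatter), so compound 1, the only one of the three carrying a dimethylamino group, now stands apart from two different replacements. No evidence on the cause is at hand. Open, from the compounds shown here alone, is whether another amine, such as a diethylamino or morpholine group, would match compound 1 here. Also open, going by these compounds, is how a carboxylic acid or a longer chain at this place would read.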